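One methyl more on compound 1

The source may report more compounds than this note shows. Statements on the series, on what has been measured and on what is new or still open speak of the compounds shown alone.

Measured so far in a functional assay on HEK-293T cells (Homo sapiens) for cytotoxicity, read by MTT assay; a lower number here means that less compound is tolerated, a higher number that more compound is tolerated:
- compound 1 `COc1ccc(-c2nc3ccccn3c2Nc2cc(OC)c(OC)c(OC)c2)cc1O`: 10000 nM
- compound 2 `COc1ccc(-c2nc3cc(C)ccn3c2Nc2cc(OC)c(OC)c(OC)c2)cc1O`: 8000 nM
- compound 3 `COc1cc(Nc2c(C3C=Nc4ccccc43)nc3cnccn23)cc(OC)c1OC`: 12000 nM

These three values lie within the usual scatter of one another, so compound 1 stands level with the other two and no order can be drawn among them. The next compound to be tested is compound 4 `COc1ccc(-c2nc3cccc(C)n3c2Nc2cc(OC)c(OC)c(OC)c2)cc1O`. Its change from compound 1 is small: methyl in place of hydrogen on an aromatic carbon. The new methyl sits next to the ring nitrogen.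

For the measured compounds named here, only one measured step bears on this, the same kind of swap made at a different carbon to give compound 2. That step is a 1.3-fold lower number from compound 1 to compound 2 (0.10 log units; within the scatter). Going by the values given here, no compound with a methyl next to the ring nitrogen has been measured yet, so this single step is only a rough guide. In this assay, no step beyond the scatter is expected. The expected result is a 1.1-fold lower number from compound 1 to compound 4 (0.05 log units; within the scatter). Compound 4 is estimated at 9000 nM, with an expected range from 5000 nM to 16000 nM.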

Compound 4, concentration lethal to 50% of the cells: 63000 nM
For compound 4 the middle estimate is 7.0-fold (0.85 log units) below the measured one; measured number above the stated range.
By their numbers in this assay, from the lowest: compounds 2, 1 and 3 (each within the scatter of the next); then compound 4.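

In this assay, for the compounds shown here, methyl in place of hydrogen next to the ring nitrogen gives a 6.3-fold higher number from compound 1 to compound 4 (0.80 log units; beyond the scatter), a step beyond the scatter and the first clear change in this small set. The same swap at a different carbon of that ring gives a 1.3-fold lower number from compound 1 to compound 2 (0.10 log units; within the scatter), which stays within the scatter, so in this pair of steps the place of the methyl matters more than its mere presence. Nothing available here accounts for the difference between the two positions.

On these data alone, whether an ethyl group, a chlorine or an amine on this same carbon would give a step of similar size remains open. So does whether a methyl here would have the same effect on a different core, since the only evidence comes from the core of compound 1.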